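Fluoro to 4-Methoxybenzyl: From Compound 2 to Compound 3

A few compounds are considered here, and "the series" means these few. Any claim that something is new, unique, unknown or untested is made for them only; others in the source may bear on it.

Compound 1 `O=C1Nc2ccc(Br)cc2/C1=C/c1cccc(OCc2cn(Cc3ccccc3)nn2)c1`: > 50000 nM in a functional assay on MDA-MB-231 cells (Homo sapiens) for inhibition, read by MTT assay, with a stated time of 48 h (a lower number here means a stronger inhibitor, a higher number a weaker inhibitor), a limit.
Compound 2 `O=C1Nc2ccc(F)cc2/C1=C\c1cccc(OCc2cn(Cc3ccccc3)nn2)c1`: > 50000 nM in this assay, a limit.

Compound 2 stands at the limit of this assay, as does compound 1 (the limit of > 50000 nM in this assay, at which 2 of the 2 values shown sit). Compound 3 `COc1ccc(Cc2ccc3c(c2)/C(=C\c2cccc(OCc4cn(Cc5ccccc5)nn4)c2)C(=O)N3)cc1` differs from compound 2 by 4-methoxybenzyl in place of fluoro on an aromatic carbon. Within the data shown here, no measured pair shows what such a change does here, so the expected step from compound 2 to compound 3 is given as an at least 1.2-fold lower number from compound 2 to compound 3 (0.09 log units; that floor lies within the scatter), uncertain in direction and size. Compound 3 is estimated at 40000 nM, between 8000 nM and 200000 nM, with a real chance that only a limit is reported.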

Compound 3, half-maximal inhibitory concentration: > 50000 nM
Compound 3 was reported as a limit; the forecaster's own chance of this, stated with the estimate: 60%; at least 1.2-fold (0.09 log units) between middle value and limit.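

Compound 3, like compound 2, is reported only as a limit, so no step can be read between them: the limit of > 50000 nM in this assay, at which 3 of the 3 values shown sit.

The compounds shown leave open whether any change to the shared core would give a measured number in this assay.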